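Swapping the sulfonyl group for a furanylmethyl on the amine

A few compounds are considered here, and "the series" means these few. Any claim that something is new, unique, unknown or untested is made for them only; others in the source may bear on it.

Measured compounds:
compound 1 `C[C@@H](NCC1CCN(CCCc2c[nH]c3ccc(-n4cnnc4)cc23)CC1)c1ccccc1` — 14 nM
compound 2 `CN(C1CCN(CCCc2c[nH]c3ccc(-n4cnnc4)cc23)CC1)S(=O)(=O)c1ccccc1` — 10 nM

Compound 2 was tested in an assay on CHO cells for displacement of a labelled ligand from 5-hydroxytryptamine receptor 1B (Homo sapiens) (a lower number here means a stronger inhibitor, a higher number a weaker inhibitor), and gives 10 nM, the lowest of the two numbers; its nearest neighbour, compound 1, gives 14 nM, which lies within the scatter. Compound 3 `CN(Cc1ccco1)C1CCN(CCCc2c[nH]c3ccc(-n4cnnc4)cc23)CC1` is yet to be measured in this assay. Its change from compound 2 is (furan-2-yl)methyl in place of phenylsulfonyl on an amine nitrogen. Going by the values given here, the only measured step touching this part of the shared core is a 1.4-fold lower number from compound 1 to compound 2 (0.15 log units; within the scatter), a move from a ((1-phenylethyl)amino)methyl substituent to a methyl(phenylsulfonyl)amino one that changed the number by less than the scatter. Compound 3 returns from a sulfonyl to an alkyl substituent on the amine nitrogen, so on that one step a change no larger than the scatter is expected, in no firm direction. Compound 3 is therefore estimated to give about 12 nM in this assay, with a range from 4 nM to 40 nM, implying a step of a 1.2-fold higher number from compound 2 to compound 3 (0.08 log units; within the scatter). The evidence is thin: one step, within the scatter.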

Compound 3, half-maximal inhibitory concentration: 89 nM
Compound 3: middle estimate off by 7.4-fold (0.87 log units), on the low side; the measured number lies above the stated range.
By their numbers in this assay, from the lowest: compounds 2 and 1 (each within the scatter of the next); then compound 3.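

In this assay, the group on the amine nitrogen proves to matter: putting (furan-2-yl)methyl in place of phenylsulfonyl gives an 8.9-fold higher number from compound 2 to compound 3 (0.95 log units; beyond the scatter) and shows a sensitivity that the earlier step, a 1.4-fold lower number from compound 1 to compound 2 (0.15 log units; within the scatter) and so no larger than the scatter, gave no sign of. Measured against the other substituent, the change to ((furan-2-yl)methyl)(methyl)amino gives a 6.4-fold higher number from compound 1 to compound 3 (0.80 log units; beyond the scatter) as well, so among these three the two substituents holding a phenyl group, in compound 1 and compound 2, stand level within the scatter, while compound 3, holding a furan-2-yl ring instead, stands apart. Nothing shown here accounts for this gap.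

Three compounds cannot separate the ring from its link to the nitrogen: a benzyl group on the same amine nitrogen would keep the phenyl ring with a methylene link as in compound 3, and a furan-2-ylsulfonyl group would keep the sulfonyl while carrying the furan. On these data alone, it also remains open whether any aromatic ring is needed at this position, which a plain ethyl group on that nitrogen would test.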